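Swapping an Ester Arm for a Fluorophenyl Acid

A few compounds are considered here, and "the series" means these few. Any claim that something is new, unique, unknown or untested is made for them only; others in the source may bear on it.

Compound 2 `COC(=O)CNc1cc(CS(=O)(=O)/C=C/c2c(OC)cc(OC)cc2OC)ccc1OC`: 100 nM
Compound 1 `COc1ccc(CS(=O)(=O)/C=C/c2cc(OC)c(OC)cc2OC)cc1N`: 250 nM

Both numbers come from a functional assay on DU-145 cells (Homo sapiens) for cytotoxicity, read by trypan blue exclusion, with a stated time of 96 h; a higher number here means a weaker inhibitor, a lower number a stronger inhibitor. In this assay compound 2 gives the lower of the two numbers, and compound 1 sits above it by a gap beyond the usual scatter. Compound 3 `COc1cc(OC)c(/C=C/S(=O)(=O)Cc2ccc(OC)c(NC(C(=O)O)c3ccc(F)cc3)c2)c(OC)c1` differs from compound 2 in one place: carboxy(4-fluorophenyl)methyl in place of (methoxycarbonyl)methyl on a nitrogen on an aromatic ring. Among the measured compounds shown here, no measured pair shows this change, so its size is open. A modest shift toward a weaker result is expected, a 3.0-fold higher number from compound 2 to compound 3 (0.48 log units; beyond the scatter). Compound 3 is therefore estimated at 300 nM, with a range from 80 nM to 1200 nM.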

Compound 3, half-maximal inhibitory concentration: 150 nM
Beside the measured number, compound 3's estimate is 2.0-fold (0.30 log units) above it; measured number inside the range.
By their numbers in this assay, from the lowest: compounds 2, 3 and 1 (each within the scatter of the next, the first and the last beyond it).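

On the nitrogen on an aromatic ring, carboxy(4-fluorophenyl)methyl in place of (methoxycarbonyl)methyl gives a 1.5-fold higher number from compound 2 to compound 3 (0.18 log units; within the scatter) in this assay. So this position takes a much larger group, one that brings an extra aromatic ring and a carboxy group, with no change beyond the scatter. Nothing available explains why the two groups read alike.

The compounds shown do not separate the added ring from the swap of ester for acid. A plain carboxymethyl group on that nitrogen would help tell these two parts apart.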